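The compounds below may be only part of what the source reports. "The series", "measured", "known", "first", "only" and "open" are said of these compounds alone.

Among the measured compounds shown here, compound 3, `CC(=O)c1ccccc1CC[C@H](SC[C@@H](C)C(=O)O)c1cccc(/C=C/c2ccc3ccc(Cl)cc3n2)c1`, gives 11 mL/min/kg in an in vivo ADME assay on the whole organism (plasma) for pharmacokinetics, with Rattus norvegicus as the target, at a dose of 5 mg/kg by the intravenous route (on this read-out lower numbers stand for slow clearance and higher numbers for fast clearance), the highest of the three numbers measured so far. Its partners are compound 1, `CC(=O)c1cccc(CC[C@H](SC[C@@H](C)C(=O)O)c2cccc(/C=C/c3ccc4ccc(Cl)cc4n3)c2)c1`, which gives 2 mL/min/kg in this assay, and compound 2, `C[C@H](CS[C@@H](CCc1cccc(CO)c1)c1cccc(/C=C/c2ccc3ccc(Cl)cc3n2)c1)C(=O)O`, which gives 2.5 mL/min/kg. The step of a 5.5-fold higher number from compound 1 to compound 3 (0.74 log units; beyond the scatter) and the step of a 4.4-fold higher number from compound 2 to compound 3 (0.64 log units; beyond the scatter) both lie beyond the scatter and both go with the move of the substituted phenyl group to its 2-substituted form, while the step of a 1.3-fold higher number from compound 1 to compound 2 (0.10 log units; within the scatter) shows that exchanging acetyl for hydroxymethyl changes little. Compound 4, `C[C@H](CS[C@@H](CCc1ccccc1CC(C)(C)O)c1cccc(/C=C/c2ccc3ccc(Cl)cc3n2)c1)C(=O)O`, keeps the 2-substituted arrangement of compound 3 and differs from it only in one place: 2-hydroxy-2-methylpropyl in place of acetyl on an aromatic carbon. Since compound 1 and compound 2 show the acetyl-to-hydroxy exchange to be small, and compound 3 sets the level for the 2-substituted form, compound 4 is expected to stay near compound 3, with a step of a 1.4-fold lower number from compound 3 to compound 4 (0.14 log units; within the scatter) that may fall within the scatter. Compound 4 is therefore estimated at 8 mL/min/kg, with a range from 3 mL/min/kg to 20 mL/min/kg.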

Compound 4, clearance: 33 mL/min/kg
Compound 4: the middle estimate sits 4.1-fold (0.62 log units) below what was measured, outside the stated range (above it).
By their numbers in this assay, from the lowest: compounds 1 and 2 (each within the scatter of the next); then compound 3; then compound 4.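

In this assay, the exchange on this aromatic carbon is not a small one when the group sits on a 2-substituted phenyl: 2-hydroxy-2-methylpropyl in place of acetyl gives a 3.0-fold higher number from compound 3 to compound 4 (0.48 log units; beyond the scatter), whereas hydroxymethyl in place of acetyl on the 3-substituted phenyl had stayed within the scatter. Among the compounds shown here, the changes of the whole phenyl group reach a 13-fold higher number from compound 2 to compound 4 (1.12 log units; beyond the scatter) and a 17-fold higher number from compound 1 to compound 4 (1.22 log units; beyond the scatter), both larger than any step among the earlier compounds. Nothing in the data shown accounts for this rise.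

The compounds shown leave open whether the rise follows the hydroxy group, the longer chain or its place on the ring. 3-(2-Hydroxy-2-methylpropyl)phenyl would separate place from group, and a 2-hydroxyethyl or a carboxylic acid on the same aromatic carbon would test the chain and its end.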